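Dodecyl-tetrazole amides: methoxy to dimethylamino on the aryl

A few compounds are considered here, and "the series" means these few. Any claim that something is new, unique, unknown or untested is made for them only; others in the source may bear on it.

compound 1 `CCCCCCCCCCCCn1nnc(C(C(=O)Nc2c(OC)ncnc2OC)c2ccccc2)n1` — 39%
compound 2 `CCCCCCCCCCCCn1nnc(C(C(=O)Nc2c(OC)cc(OC)cc2OC)c2ccc(OC)cc2)n1` — 61%

In an assay on isolated protein for inhibition of sterol O-acyltransferase 1 (Mus musculus), tested at 0.1 uM (on this read-out lower numbers stand for less inhibition and higher numbers for more inhibition at the one concentration tested (going by the name of the read-out)), compound 2 gives 61%, the higher of the two numbers measured, while compound 1 gives 39%, a gap beyond the usual scatter. Compound 3 `CCCCCCCCCCCCn1nnc(C(C(=O)Nc2c(OC)cc(OC)cc2OC)c2ccc(N(C)C)cc2)n1` is not yet measured; it differs from compound 2 in one place: dimethylamino in place of methoxy on an aromatic carbon. For the measured compounds named here, no single-change step between measured compounds is available, so the size of this change cannot be read from the data. Expected is a step no larger than the scatter, in either direction, a number 1 percentage points lower from compound 2 to compound 3 (within the scatter). Compound 3 is therefore estimated at 60%, within a range from 35% to 85%.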

Compound 3, a percentage reported as inhibition, at one concentration (the size of the read-out at that concentration, not a potency): 0%
The estimate for compound 3 lay 60 percentage points above the measured number; the measured number lies below the stated range.
By their numbers in this assay, from the lowest: compound 3; then compound 1; then compound 2.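

The exchange of methoxy for dimethylamino on this aromatic carbon, para to a large group, gives in this assay a number 61 percentage points lower from compound 2 to compound 3 (beyond the scatter), so the position is far from indifferent to its substituent. Counts of hydrogen-bond donors and acceptors stay the same across the change and do not separate the two compounds. Nothing measured here explains the size of the step.

Open, going by these compounds, is whether a primary amine, a hydroxyl group or a chlorine at this position would retain inhibition. Also open, on these data alone, is whether the same exchange would have a comparable effect with another amide partner on the shared core.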